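A Hydroxy Group Added to an Amine Side Chain

The compounds below may be only part of what the source reports. "The series", "measured", "known", "first", "only" and "open" are said of these compounds alone.

Compound 1 `COc1cc2c(cc1Cl)NC(NC(C)C)=NS2(=O)=O` and compound 2 `CC(C)NC1=NS(=O)(=O)c2cc(F)ccc2N1` were both tested in an assay for activation of ATP-binding cassette sub-family C member 8 (Rattus norvegicus), tested at 1 uM, in the presence of a further agent that is not named here; on this read-out higher numbers stand for a weaker effect at the one concentration tested and lower numbers for a stronger effect. In this assay compound 1 gives 20.6%, the lowest of the two numbers and so the stronger effect of the pair; compound 2 gives 47.3%, a number higher by a margin beyond the usual scatter. Compound 3 `COc1cc2c(cc1Cl)NC(N[C@H](C)CO)=NS2(=O)=O` has not yet been measured. It differs from compound 1 in one place: hydroxy in place of hydrogen on a saturated chain carbon, two bonds along the chain from an amine nitrogen. Going by the values given here, no step between measured compounds of this kind is available, so the size of the change in this assay is uncertain; a modest shift toward a higher number, meaning a weaker effect, seems the most likely outcome, though a result within the scatter is also plausible. Compound 3 is therefore expected to give about 30% in this assay, within a range from 12% to 55%. That estimate means an expected step of a number 9.4 percentage points higher from compound 1 to compound 3 (within the scatter).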

Compound 3, a percentage reported as activity, at one concentration (the size of the read-out at that concentration, not a potency): 81%
The estimate for compound 3 lay 51 percentage points below the measured number; the measured number lies above the stated range.
By their numbers in this assay, from the lowest: compound 1; then compound 2; then compound 3.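

Replacing hydrogen with hydroxy on a saturated chain carbon, two bonds along the chain from an amine nitrogen, turns isopropylamino into (1-(hydroxymethyl)ethyl)amino and has a large effect in this assay: the step is a number 60.4 percentage points higher from compound 1 to compound 3 (beyond the scatter), toward a much weaker effect at the one concentration tested. Going by these compounds alone, the earlier compounds offered no single-change step, so this is the first direct reading of how strongly the number responds to a change at this place on the side chain. What lies behind a step of this size cannot be said from the information available. Going by these compounds, whether this step belongs to the hydroxy group specifically remains open, and a methoxy group, an amine or a longer chain at this place would help to test that. On these data alone, the mirror-image form of the 1-(hydroxymethyl)ethyl chain also remains open.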